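Mirror Image of a Methylated Diketopiperazine Agonist

A few compounds are considered here, and "the series" means these few. Any claim that something is new, unique, unknown or untested is made for them only; others in the source may bear on it.

Compound 3 `CCCCCCCCN1C(=O)[C@H](Cc2ccc(-c3cc(OC)c(OC)c(OC)c3)cc2)N(C)C(=O)[C@H]1C` gives 120 nM in a functional assay for agonist activity at follicle-stimulating hormone receptor (Homo sapiens), read by a luciferase reporter (on this read-out higher numbers stand for an effect only at larger amounts of compound and lower numbers for an effect already at smaller amounts), which places it second highest of the three numbers recorded: compound 1 `CCCCCCCCN1CC(=O)N(C)[C@@H](Cc2ccc(-c3cc(OC)c(OC)c(OC)c3)cc2)C1=O` gives 400 nM and compound 2 `CCCCCCCCN1C(=O)[C@H](Cc2ccc(-c3cc(OC)c(OC)c(OC)c3)cc2)N(C)C(=O)[C@@H]1C` gives 13 nM. The methyl substitutions gave a 31-fold lower number from compound 1 to compound 2 (1.49 log units; beyond the scatter) and a 3.3-fold lower number from compound 1 to compound 3 (0.52 log units; beyond the scatter), and the configurational step gave a 9.2-fold higher number from compound 2 to compound 3 (0.97 log units; beyond the scatter), consistent with the fact that compounds 2 and 3 differ only in the configuration as drawn.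

Compound 4 `CCCCCCCCN1C(=O)[C@@H](Cc2ccc(-c3cc(OC)c(OC)c(OC)c3)cc2)N(C)C(=O)[C@@H]1C` differs from compound 3 as follows: the two compounds have the same atoms and bonds and differ only in configuration as drawn: 2 of 2 stereo elements differ (all stereocentres are inverted: mirror images); a stereocentre at a saturated ring carbon is drawn S in compound 3 and R in compound 4; a stereocentre at a saturated ring carbon is drawn R in compound 3 and S in compound 4. Among the measured compounds shown here, no measured pair among compounds 1 to 3 inverts every stereocentre at once; the only configurational step recorded, from compound 2 to compound 3, already moved the number by a 9.2-fold higher number from compound 2 to compound 3 (0.97 log units; beyond the scatter) with a single centre changed. For the measured compounds named here, all three measured compounds share the configuration drawn at the benzyl-bearing ring carbon, and compound 4 is the first to invert it, so the change is expected to push the number upward, probably by at least as much as that single-centre step and with wide uncertainty.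

Compound 4 is therefore estimated at 1200 nM in this assay, within 250 nM to 6000 nM, corresponding to an expected step of a 10-fold higher number from compound 3 to compound 4 (1.00 log units; beyond the scatter).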

Compound 4, half-maximal effective concentration: 68 nM
Compound 4: the middle estimate sits 18-fold (1.25 log units) above what was measured; the whole stated range lies above it.
By their numbers in this assay, from the lowest: compound 2; then compounds 4 and 3 (each within the scatter of the next); then compound 1.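

Inverting both stereocentres together does not separate the two mirror images in this assay: the step is a 1.8-fold lower number from compound 3 to compound 4 (0.25 log units; within the scatter), so the benzyl-bearing ring carbon can take either configuration here without a readable change, provided the methyl-bearing ring carbon is inverted with it. Inverting the benzyl-bearing ring carbon alone does count, with a 5.2-fold higher number from compound 2 to compound 4 (0.72 log units; beyond the scatter), which shows that changing either stereocentre of compound 2 gives up its low number, and that the effect of one centre depends on the configuration of the other. Since the atoms and bonds stay the same, these shifts rest on configuration alone: the fact that compounds 2 and 4 differ only in the configuration as drawn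

The compounds shown leave open what the mirror image of compound 2 would give, and so whether the low number of compound 2 belongs to that one arrangement of both centres or to its mirror-image pair as well. They also leave open whether an ethyl group or a hydroxymethyl group on the same ring carbon would behave like the methyl, in either configuration.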